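The compounds below may be only part of what the source reports. "The series", "measured", "known", "first", "only" and "open" are said of these compounds alone.

Of the compounds shown here, three built on one shared core have been tested in a functional assay on SW-620 cells (Homo sapiens) for inhibition, read by MTT assay, with a stated time of 72 h; on this read-out lower numbers stand for stronger inhibition and higher numbers for weaker inhibition. Compound 1 `O=c1cc(Cn2cc(C3CC3)nn2)c2ccc(O)cc2o1` carries a cyclopropyl group; in this assay compound 1 reaches only the limit of the assay, > 100000 nM. Compound 2 `O=c1cc(Cn2cc(CCCO)nn2)c2ccc(O)cc2o1` carries a 3-hydroxypropyl group instead; in this assay compound 2 likewise gives only a limit, > 100000 nM. Compound 3 `O=c1cc(Cn2cc(CCCCO)nn2)c2ccc(O)cc2o1` carries a 4-hydroxybutyl group; in this assay compound 3 also stops at a limit, > 100000 nM. Because of the limit of > 100000 nM in this assay, at which 3 of the 3 values shown sit, none of the steps among these three can be read: one step is a step that the two limits leave unreadable from compound 1 to compound 2, another is a step that the two limits leave unreadable from compound 1 to compound 3, and the third is a step that the two limits leave unreadable from compound 2 to compound 3. Compound 4 `CC(C)(C)c1cn(Cc2cc(=O)oc3cc(O)ccc23)nn1` differs from compound 3 in a single place: tert-butyl in place of 4-hydroxybutyl on an aromatic carbon. The two steps that end at compound 3 are the ones that bear on this change, and both are unreadable, so neither a size nor a direction can be foreseen in this assay; the likeliest outcome is another limit. Compound 4 is therefore expected to give about 100000 nM, with a range from 30000 nM to 300000 nM. The expected step from compound 3 to compound 4 is accordingly a number no higher from compound 3 to compound 4 (the limit leaves the size open).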

Compound 4, half-maximal inhibitory concentration: > 100000 nM
Compound 4 ended at the assay's limit (the forecaster's own chance of this, stated with the estimate: 85%); the middle value sits exactly at the limit.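

Among the compounds shown here, no step from compound 1, compound 2 or compound 3 to compound 4 can be read in this assay, because every value is a limit and not a number: the limit of > 100000 nM in this assay, at which 4 of the 4 values shown sit.

The compounds shown leave open how the cyclopropyl, 3-hydroxypropyl, 4-hydroxybutyl and tert-butyl groups rank against one another in this assay.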